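One ring swap at a reporting limit

This account rests on a few compounds, and the source may have more. Where it says the series, first, only, none or still open, it means among the compounds named here.

Measured in an ADME assay on HEK293 cells (Homo sapiens) for cytotoxicity, read by ATP content, with a stated time of 6 h; on this read-out lower numbers stand for higher toxicity in this test and higher numbers for lower toxicity in this test:
- compound 1 `Cc1nc(CNc2nc(N)nc3ccn(Cc4ccccn4)c23)cs1` gives > 24000 nM, a limit
- compound 2 `Cc1coc(CNc2nc(N)nc3ccn(Cc4ccccn4)c23)n1` gives > 24000 nM, a limit

Compound 2 stands at > 24000 nM, which is a limit and not a number. Neither measured compound has a readable value, as shown by the limit of > 24000 nM in this assay, at which 2 of the 2 values shown sit. Compound 3 `Nc1nc(NCc2nccs2)c2c(ccn2Cc2ccccn2)n1` carries 1,3-thiazol-2-yl in place of 4-methyl-1,3-oxazol-2-yl on a saturated chain carbon bound to a nitrogen on an aromatic ring. Going by the values given here, the one measured step that bears on this change is a step that the two limits leave unreadable from compound 1 to compound 2, also a swap of the ring on that carbon, and its size cannot be read. No number therefore sizes such a swap in this assay. Compound 2 at > 24000 nM is the only anchor, so no change beyond the scatter is expected. The expected move is a step that the limit leaves unreadable from compound 2 to compound 3, with no firm direction. Compound 3 is estimated at 30000 nM, with an expected range from 16000 nM to 60000 nM.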

Compound 3, half-maximal cytotoxic concentration: > 24000 nM
Compound 3 ended at the assay's limit (the forecaster's own chance of this, stated with the estimate: 85%); the middle value does not contradict the limit.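

Compound 3 gives > 24000 nM as a limit and not a number. The steps among compound 1, compound 2 and compound 3 therefore cannot be read: the limit of > 24000 nM in this assay, at which 3 of the 3 values shown sit. Still open, from the compounds shown here alone, is whether swapping the ring on that saturated chain carbon changes the toxicity seen in this assay at all.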